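This account rests on a few compounds, and the source may have more. Where it says the series, first, only, none or still open, it means among the compounds named here.

Compound 1, `COc1ccc(OC(C)(C)C2OCC(C/C=C\CCC(=O)O)C(c3cccnc3)O2)cc1` — 41 nM
Compound 2, `Cc1ccc(OC(C)(C)C2OCC(C/C=C\CCC(=O)O)C(c3cccnc3)O2)cc1` — 360 nM
Compound 3, `Cc1ccc(SC(C)(C)C2OCC(C/C=C\CCC(=O)O)C(c3cccnc3)O2)c([N+](=O)[O-])c1` — 30 nM

The three measured compounds share one core and were tested in an assay for inhibition of Thromboxane-A synthase (Homo sapiens), using microsomes; on this read-out higher numbers stand for weaker inhibition and lower numbers for stronger inhibition. Compound 2 gives 360 nM, compound 1 gives 41 nM, and compound 3 gives 30 nM. The step of an 8.8-fold lower number from compound 2 to compound 1 (0.94 log units; beyond the scatter) comes from methoxy in place of methyl on an aromatic carbon. The two cores differ as a group of 11 heavy atoms (7 carbon, 1 nitrogen, 2 oxygen, 1 sulfur; one six-membered aromatic ring of carbon only) in place of a group of 8 heavy atoms (7 carbon, 1 oxygen; one six-membered aromatic ring of carbon only), on a saturated chain carbon bound to two saturated chain carbons and a saturated ring carbon, which gives a 12-fold lower number from compound 2 to compound 3 (1.08 log units; beyond the scatter), while a 1.4-fold lower number from compound 1 to compound 3 (0.14 log units; within the scatter) is within the scatter.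

Compound 4, `COc1ccc(SC(C)(C)C2OCC(C/C=C\CCC(=O)O)C(c3cccnc3)O2)c([N+](=O)[O-])c1`, has not yet been measured in this assay. It differs from compound 3 by methoxy in place of methyl on an aromatic carbon. This is the same kind of change as that from compound 2 to compound 1, but the place is not identical: in compound 4 the methoxy sits on an aromatic carbon meta to a nitro group, whereas in compound 1 it sits only para to a large group. Because an 8.8-fold lower number from compound 2 to compound 1 (0.94 log units; beyond the scatter) was a modest step beyond the scatter, a step of the same direction is expected for compound 4, though with a single example its size is uncertain, so a 3.8-fold lower number from compound 3 to compound 4 (0.57 log units; beyond the scatter) is estimated. Compound 4 is therefore expected to give about 8 nM, in the range 3 nM to 30 nM.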

Compound 4, half-maximal inhibitory concentration: 40 nM
For compound 4 the middle estimate is 5.0-fold (0.70 log units) below the measured one; the measured number lies above the stated range.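

In this assay, methoxy in place of methyl gave a 1.3-fold higher number from compound 3 to compound 4 (0.12 log units; within the scatter), so the clear step seen on the core of compound 2 did not reappear on the core of compound 3. Going by these compounds alone, the same change therefore behaves differently on the two cores, and the size of the step on one cannot be carried over to the other: the same change on two cores in this assay, an 8.8-fold lower number (0.94 log units; beyond the scatter) from compound 2 to compound 1 and a 1.3-fold higher number (0.12 log units; within the scatter) from compound 3 to compound 4, 12-fold (1.07 log units) apart, beyond the scatter of two such steps This does not show what sets the two cores apart: they differ in both sulfur for oxygen and the added nitro group, and with only one pair on each core, the data cannot separate these two differences or say how general the contrast is.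

The compounds shown leave open how the change would read on a core carrying only the sulfur or only the nitro group. On these data alone, it also remains open how a different group at the same place on the ring, such as ethoxy, chlorine or an amine, would compare on either core.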